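The compounds below may be only part of what the source reports. "The series", "measured", "known", "first", "only" and "open" are said of these compounds alone.

Measured so far:
- compound 1, `O=C(CN(c1ncnc2c1ncn2C1CCCCO1)C1CC1)N[C@@H](CCC(=O)OCc1ccccc1)C(=O)OCc1ccccc1`: 25.2%
- compound 2, `N=C(N)NCCC[C@H](NC(=O)CN(c1nc(Cl)nc2[nH]cnc12)C1CC1)C(=O)OCc1ccccc1`: 30.4%

In a functional assay on the whole organism (Tail, strain ICR) with Mus musculus as the target, in the tail flick test, with a stated time of 90 min, at a dose of 25 umol/kg by the oral route (a lower number here means a weaker effect, a higher number a stronger effect of the compound at the dose given), compound 1 gives 25.2%, and compound 2 gives 30.4%. The gap between these two numbers lies within the usual scatter of this assay, so the two compounds cannot be told apart on the data at hand; compound 1 is simply one of two comparable values. Compounds 1 and 2 also differ from each other in more than one place, so no single step can be read off between them.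

The unmeasured compound 3, `O=C(CN(c1ncnc2c1ncn2C1CCCCO1)C1CC1)N[C@@H](CO)C(=O)OCc1ccccc1`, follows from compound 1 by one change: hydroxy in place of (benzyloxycarbonyl)methyl on a saturated chain carbon, two bonds along the chain from an amide-type nitrogen and a carbonyl carbon. Among the compounds with values here, no pair of measured compounds differs by this change, so nothing in the present numbers sets its size or direction. Within the data shown here, with the two measured values sitting where they do and with no step of this kind to go by, the step from compound 1 to compound 3 is expected to stay within the scatter, as a number 1.2 percentage points lower from compound 1 to compound 3 (within the scatter). Compound 3 is accordingly estimated at 24% in this assay, with a range from 10% to 40%.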

Compound 3, a percentage reported as activity, at one dose (the size of the read-out at that dose, not a potency): 32.2%
For compound 3 the middle estimate is 8.2 percentage points below the measured one; measured number inside the range.
By their numbers in this assay, from the lowest: compounds 1, 2 and 3 (each within the scatter of the next).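

In this assay, the swap on this saturated chain carbon, two bonds along the chain from an amide-type nitrogen and a carbonyl carbon, gives a number 7 percentage points higher from compound 1 to compound 3 (within the scatter). Within the data shown here, this is the first reading at this place: 2-(benzyloxycarbonyl)ethyl, with its six-membered aromatic ring, can give way to hydroxymethyl in this pair without a step beyond the scatter, so the loss of the (benzyloxycarbonyl)methyl part, 11 heavy atoms, and the entry of hydroxy, 1 heavy atom, leave the oral read-out at this one dose unresolved from that of compound 1. The data give no explanation for this, and no measurement bears on the cause of the result.

Still open, as far as these compounds go, is whether any group at this place can move the read-out beyond the scatter, for instance an amine, a carboxylic acid, a plain methyl or a longer chain ending in hydroxy. Also open, from the compounds shown here alone, is whether the same tolerance holds when the benzyl ester on the carbonyl carbon or the tetrahydropyranyl-bearing core of compound 1 is changed, and whether it holds at other doses.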